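Swapping the tetrazole of compound 1 for carboxymethoxy

This account rests on a few compounds, and the source may have more. Where it says the series, first, only, none or still open, it means among the compounds named here.

Compound 1 `CC(C)(C)c1ccc(C(=O)NCc2ccc(-c3nnn[nH]3)cc2)cc1` gives 120 nM in an assay on HeLa cells with Bile acid receptor (Homo sapiens) as the target, read by a luciferase reporter, with a stated time of 24 h (a higher number here means that more compound is needed for the effect, a lower number that less compound is needed), the second highest of the three numbers at hand. Compound 2 `CSc1ccc(CNC(=O)c2ccc(C(C)(C)C)cc2)cc1` gives 100 nM, and the step of a 1.2-fold lower number from compound 1 to compound 2 (0.08 log units; within the scatter) lies within the scatter. Compound 3 `O=C(O)c1ccc(CNC(=O)c2ccc(-c3ccccc3)cc2)cc1` gives 440 nM, a higher number than compound 1 beyond the scatter, but it differs from compound 1 in more than one place. The unmeasured compound 4 `CC(C)(C)c1ccc(C(=O)NCc2ccc(OCC(=O)O)cc2)cc1` carries the change (carboxymethoxy in place of 1H-tetrazol-5-yl on an aromatic carbon). Within the data shown here, only the step from compound 1 to compound 2 alters the same position, and it stayed within the scatter, yet it introduced no carboxylic acid. Compound 3, which carries one, shows the higher number. The step of a 1.8-fold higher number from compound 1 to compound 4 (0.26 log units; within the scatter) is therefore expected to be a modest rise. Compound 4 is estimated at 220 nM, ranging from 70 nM to 700 nM.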

Compound 4, half-maximal effective concentration: 730 nM
Compound 4: the middle estimate sits 3.3-fold (0.52 log units) below what was measured, and the stated range ends below it.
By their numbers in this assay, from the lowest: compounds 2 and 1 (each within the scatter of the next); then compounds 3 and 4 (each within the scatter of the next).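

The position, on an aromatic carbon para to a large group, proved sensitive to the group it carries in this assay: carboxymethoxy gave a 6.1-fold higher number from compound 1 to compound 4 (0.78 log units; beyond the scatter) and also a 7.3-fold higher number from compound 2 to compound 4 (0.86 log units; beyond the scatter). The earlier exchange of 1H-tetrazol-5-yl for methylsulfanyl, a 1.2-fold lower number from compound 1 to compound 2 (0.08 log units; within the scatter), had shown no such separation, so carboxymethoxy stands apart from both groups. Nothing at hand bears on the reason for this rise. Still open, as far as these compounds go, is whether the rise follows the acid itself or the ether oxygen that links it, and how an amine or a longer chain would fare here.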